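Adding a Second Methoxy Group to an Aryl Semicarbazone

The source may report more compounds than this note shows. Statements on the series, on what has been measured and on what is new or still open speak of the compounds shown alone.

Going by the values given here, compound 2 `COc1cccc(/C=N/NC(=O)Nc2cccc3ccccc23)c1` has the lowest number of the two measured so far in a functional assay on the whole organism (strain Swiss albino) with Mus musculus as the target, with a stated time of 0.5 h (a higher number here means that more compound is needed for the effect, a lower number that less compound is needed), at 100 mg/kg; compound 1 `O=C(N/N=C/c1ccc(Cl)cc1Cl)Nc1cccc2ccccc12` gives 300 mg/kg. Among the compounds with values here, the one measured step, a 3.0-fold lower number from compound 1 to compound 2 (0.48 log units; beyond the scatter), exchanges the whole aryl ring and says little about a single added group. Compound 3 `COc1ccc(OC)c(/C=N/NC(=O)Nc2cccc3ccccc23)c1` differs from compound 2 by methoxy in place of hydrogen on an aromatic carbon. Within the data shown here, with no directly comparable step, a change within the scatter is expected for compound 3 in this assay, so no change at the digits printed from compound 2 to compound 3 (within the scatter). The estimate for compound 3 is 100 mg/kg, ranging from 30 mg/kg to 300 mg/kg.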

Compound 3, minimum effective dose: 300 mg/kg
Estimate against measurement, compound 3: 3.0-fold (0.48 log units) below; low and high end bracket the measured number.
By their numbers in this assay, from the lowest: compound 2; then compounds 1 and 3 (each within the scatter of the next).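

Going by these compounds alone, the single added methoxy group gives a 3.0-fold higher number from compound 2 to compound 3 (0.48 log units; beyond the scatter) in this assay and is the first change here that touches only one group. This aromatic carbon, ortho to a large group and para to a methoxy group, is therefore not a neutral place for methoxy, since more compound is needed once it is there. Nothing available here accounts for this rise.

As far as these compounds go, it remains open whether a hydroxy group or a fluorine atom on this carbon would raise the number too. From the compounds shown here alone, it is also open whether this methoxy group would do so without the other one.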